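Replacing pentyl with cyclopropyl: what compound 4 may show

A few compounds are considered here, and "the series" means these few. Any claim that something is new, unique, unknown or untested is made for them only; others in the source may bear on it.

Measured compounds:
- compound 1 `CCCCCC(C#CC(=O)OC)O/C=C/C(=O)OC` gives 1900 nM
- compound 2 `C#CC(O/C=C/C(=O)OC)c1ccccc1` gives 26000 nM
- compound 3 `COC(=O)C#CC(CCc1ccccc1)O/C=C/C(=O)OC` gives 2600 nM

These numbers come from a functional assay on HBL-100 cells (Homo sapiens) for antiproliferative activity, read by sulforhodamine B assay, with a stated time of 48 h; a higher number here means a weaker inhibitor of growth, a lower number a stronger inhibitor of growth. Compound 1 and compound 3 lie within the scatter of each other, while compound 2 stands well apart with a higher number.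

Compound 4 `COC(=O)C#CC(O/C=C/C(=O)OC)C1CC1` carries cyclopropyl in place of pentyl on a saturated chain carbon bound to an oxygen on an unsaturated carbon and a triple-bonded carbon. Among the compounds with values here, the only measured step, a 1.4-fold higher number from compound 1 to compound 3 (0.14 log units; within the scatter), changed that chain farther along, so it bears only indirectly. Compound 2 differs in more than one place and gives only a weak hint towards a higher number. Within the data shown here, no step clearly beyond the scatter is therefore expected, and the estimated step is a 1.6-fold higher number from compound 1 to compound 4 (0.20 log units; within the scatter). Compound 4 is expected at 3000 nM, with an estimated range of 1000 nM to 9000 nM.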

Compound 4, concentration for 50% growth inhibition: 250 nM
Compound 4: middle estimate off by 12-fold (1.08 log units), on the high side; the whole stated range lies above it.
By their numbers in this assay, from the lowest: compound 4; then compounds 1 and 3 (each within the scatter of the next); then compound 2.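

Within the data shown here, at this position, on a saturated chain carbon bound to an oxygen on an unsaturated carbon and a triple-bonded carbon, the identity of the group clearly matters: cyclopropyl in place of pentyl gives a 7.6-fold lower number from compound 1 to compound 4 (0.88 log units; beyond the scatter) while the only earlier step of a 1.4-fold higher number from compound 1 to compound 3 (0.14 log units; within the scatter) made a change farther along the chain. Growth inhibition therefore strengthened here with a ring of fewer heavy atoms. Nothing available explains this gain.

The compounds shown leave open whether the gain follows from the ring itself or from the removal of the longer chain. An open isopropyl group or a larger cyclohexyl ring at this position would help separate the two.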